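The compounds below may be only part of what the source reports. "The series", "measured", "known", "first", "only" and "open" are said of these compounds alone.

Measured in a functional assay on KYSE-410 cells (Homo sapiens) for antiproliferative activity, read by MTT assay, with a stated time of 72 h; on this read-out lower numbers stand for stronger inhibition and higher numbers for weaker inhibition:
- Compound 1 `O=C(Nc1ccc(Cl)cc1)c1cc(=O)[nH]c2cc(Br)ccc12`: > 20000 nM (a limit)
- Compound 2 `O=C(Nc1cccc(F)c1)c1cc(=O)[nH]c2cc(Br)ccc12`: 7300 nM
- Compound 3 `O=C(Nc1cccc(Cl)c1)c1cc(=O)[nH]c2cc(Br)ccc12`: > 20000 nM (a limit)

For the measured compounds named here, compound 2 holds the only true number here. Compound 1 and compound 3 stand only at a limit: the limit of > 20000 nM in this assay, at which 2 of the 3 values shown sit.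

Compound 4 `O=C(Nc1cccc(F)c1)c1cc(=O)[nH]c2cc(-c3ccsc3)ccc12` carries thiophen-3-yl in place of bromo (thiophen-3-yl in place of bromo on an aromatic carbon). The measured steps, an at least 2.7-fold lower number from compound 1 to compound 2 (0.43 log units; beyond the scatter) and an at least 2.7-fold higher number from compound 2 to compound 3 (0.43 log units; beyond the scatter), all concern the aryl group on the amide-type nitrogen, so they bear only indirectly: they show that single changes can move this assay beyond the scatter. Going by the values given here, no measured step touches the bromo, so the direction is uncertain. A modest step to a lower number is expected, estimated as a 2.4-fold lower number from compound 2 to compound 4 (0.39 log units; beyond the scatter). Compound 4 is expected at 3000 nM, with an estimated range of 600 nM to 15000 nM.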

Compound 4, half-maximal inhibitory concentration: 4300 nM
Beside the measured number, compound 4's estimate is 1.4-fold (0.16 log units) below it; measured number inside the range.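

The earlier compounds shown here differ only in the aryl group on the amide-type nitrogen, so this step alone speaks to the aromatic carbon that carries bromo. In this assay, replacing bromo with thiophen-3-yl gives a 1.7-fold lower number from compound 2 to compound 4 (0.23 log units; within the scatter), so this carbon accepts a five-membered aromatic ring in place of a single atom without a change beyond the scatter.

As far as these compounds go, how this carbon responds to other groups, such as an amine or a carboxylic acid, remains open. So does whether thiophen-3-yl would give the same result alongside the other aryl groups on the amide-type nitrogen.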